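A few compounds are considered here, and "the series" means these few. Any claim that something is new, unique, unknown or untested is made for them only; others in the source may bear on it.

Values in a functional assay on Raji cells (Homo sapiens) for cytotoxicity, with a stated time of 72 h; on this read-out lower numbers stand for an effect already at smaller amounts and higher numbers for an effect only at larger amounts of compound:
Compound 1 `COc1ccc(/C=C/[C@@](C)(/C=C/c2ccc(O)cc2)CCC=C(C)C)cc1`: > 26000 nM
Compound 2 `CC(C)=CCC[C@@](C)(/C=C/c1ccccc1)/C=C/c1ccc(O)cc1`: > 26000 nM
Compound 3 `CC(C)=CCC[C@@](C)(/C=C/c1ccc(C)cc1)/C=C/c1ccc(O)cc1`: > 26000 nM

Each of these entries is a limit of the assay and not a number. Compound 3 therefore has no numeric position in the series, and its entry falls under (the limit of > 26000 nM in this assay, at which 3 of the 3 values shown sit).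

The next compound is compound 4 `CC(C)=CCC[C@](C)(/C=C/c1ccc(O)cc1)/C=C/c1ccc(C#N)cc1`, with cyano in place of methyl on an aromatic carbon, para to a large group. The counted difference is cyano in place of methyl on an aromatic carbon.

Going by the values given here, three measured steps bear on this change, all at that same aromatic carbon. The nearest is a step that the two limits leave unreadable from compound 2 to compound 3. The other two are a step that the two limits leave unreadable from compound 1 to compound 3 and a step that the two limits leave unreadable from compound 1 to compound 2. Among the compounds with values here, none of them offers a size or a direction to carry over, and no measured compound has a cyano group.

No step beyond the scatter is therefore expected in this assay, and no direction can be assigned. The most likely outcome is another limit rather than a number. The expected change is a step that the limit leaves unreadable from compound 3 to compound 4. For compound 4 the estimated value is 30000 nM, with an expected range from 15000 nM to 60000 nM.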

Compound 4, half-maximal effective concentration: > 26000 nM
Compound 4 gave a limit, no number; the forecaster's own chance of this, stated with the estimate: 85%; the middle value lies beyond the limit too.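

In this assay no new step can be read: the steps joining compound 1, compound 2 and compound 3 to compound 4 all run between limits, not numbers, as the series stands at one shared limit: the limit of > 26000 nM in this assay, at which 4 of the 4 values shown sit.

The compounds shown leave open whether any group at this aromatic carbon would give a numeric value in this assay at all.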